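The source may hold more compounds than are shown below. What is called first, only, known or untested is meant among the compounds shown, and "the series" means these compounds.

Compound 1, `CCOC(=O)N1CCC(NC(=O)Nc2ccc(OC(F)(F)F)c(F)c2)CC1`, gives 0.35 ug/mL in a physicochemical assay for solubility, read by mass spectrometry, in phosphate buffer, with a stated time of 24 h, at pH 7.4 (on this read-out higher numbers stand for higher solubility and lower numbers for lower solubility), the lowest of the three numbers in hand. Compound 2, `CC[C@H](C)C(=O)N1CCC(NC(=O)Nc2ccc(OC(F)(F)F)c(Cl)c2)CC1`, gives 0.79 ug/mL in this assay, a gap from compound 1 that lies beyond the scatter; compound 3, `CC[C@H](C)C(=O)N1CCC(CC(=O)Nc2ccc(OC(F)(F)F)c(F)c2)CC1`, gives 21 ug/mL, far above compound 1. Among the compounds with values here, no single-change pair has yet been measured, so the series offers no direct step to lean on.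

Compound 4, `O=C(Nc1ccc(OC(F)(F)F)c(F)c1)NC1CCN(C(=O)C2CCOCC2)CC1`, is next in this assay. It differs from compound 1 as follows: oxan-4-yl in place of ethoxy on a carbonyl carbon. Across the whole set the urea-bearing compounds sit low, so compound 4 is expected to move only a little, with a small upward step a 2.3-fold higher number from compound 1 to compound 4 (0.36 log units; beyond the scatter) near the edge of the scatter. Compound 4 is estimated at 0.8 ug/mL, within 0.2 ug/mL to 3.5 ug/mL.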

Compound 4, solubility: 77 ug/mL
Compound 4: the middle estimate sits 96-fold (1.98 log units) below what was measured; measured number above the stated range.
By their numbers in this assay, from the lowest: compound 1; then compound 2; then compound 3; then compound 4.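

The group on the carbonyl carbon is a strong lever in this assay since oxan-4-yl in place of ethoxy gives a 220-fold higher number from compound 1 to compound 4 (2.34 log units; beyond the scatter) with the urea and the rest of the core of compound 1 unchanged. A urea therefore does not by itself hold a compound low, as compound 4 shows. Nothing measured here bears on the reason for a step of this size.

As far as these compounds go, it remains open whether the step follows the ring, the ring oxygen or the loss of ethoxy. A cyclohexyl group or a methoxyethyl chain on the same carbonyl carbon would help separate these.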